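The compounds below may be only part of what the source reports. "The series", "measured", "known", "first", "only" and "open" are said of these compounds alone.

Measured compounds in a functional assay on DU-145 cells (Homo sapiens) for cytotoxicity; a higher number here means a weaker inhibitor of growth, a lower number a stronger inhibitor of growth:
- compound 1 `OCCCCC#Cc1ccccc1C#Cc1ccccc1`: 5220 nM
- compound 2 `COc1ccccc1C#Cc1ccccc1C#CCCCCO`: 14300 nM
- compound 3 `CSc1ccccc1C#Cc1ccccc1C#CCCCCO`: 4700 nM

Compound 3 has the lowest number of the three in this assay, though its gap to compound 1 is within the scatter; only compound 2 stands clearly apart from it. Compound 4 `OCCCCC#Cc1ccccc1C#Cc1ccccc1C(F)(F)F` differs from compound 3 at one place: trifluoromethyl in place of methylsulfanyl on an aromatic carbon, on an aromatic carbon of a six-membered aromatic ring of carbon only, ortho to a large group.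

Within the data shown here, no measured step introduces a trifluoromethyl group, so the three known steps bear on it only indirectly. They show that a substituent at this carbon shifts the number by a modest amount at most: a 2.7-fold higher number from compound 1 to compound 2 (0.44 log units; beyond the scatter), a 1.1-fold lower number from compound 1 to compound 3 (0.05 log units; within the scatter), and a 3.0-fold lower number from compound 2 to compound 3 (0.48 log units; beyond the scatter). In this assay the expected step from compound 3 to compound 4 is therefore a 1.2-fold higher number from compound 3 to compound 4 (0.07 log units; within the scatter), small and with an uncertain direction. Compound 4 is expected to give about 5500 nM in this assay, with a likely range from 2000 nM to 15000 nM.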

Compound 4, concentration for 50% growth inhibition: 6100 nM
Beside the measured number, compound 4's estimate is 1.1-fold (0.04 log units) below it; the range from low to high includes it.
By their numbers in this assay, from the lowest: compounds 3, 1 and 4 (each within the scatter of the next); then compound 2.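

In this assay, trifluoromethyl at this aromatic carbon, with more heavy atoms than methylsulfanyl and no hydrogen-bond acceptor, gives a number that cannot be told apart from those with hydrogen or methylsulfanyl there: the data show a 1.2-fold higher number from compound 1 to compound 4 (0.07 log units; within the scatter) and a 1.3-fold higher number from compound 3 to compound 4 (0.11 log units; within the scatter) as the two steps. Methoxy now stands apart from a third group, with a 2.3-fold lower number from compound 2 to compound 4 (0.37 log units; beyond the scatter) as a further step beyond the scatter, so among these four compounds only compound 2 differs clearly from the rest. Nothing available explains why methoxy alone behaves this way.

As far as these compounds go, whether an amine or a carboxylic acid on this carbon would stay with hydrogen, methylsulfanyl and trifluoromethyl or part from them as methoxy does remains open. So does the effect of a longer chain in place of the hydroxyl-bearing chain of the shared core.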